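Cyclohexyl for isopropyl on a sulfur

The source may report more compounds than this note shows. Statements on the series, on what has been measured and on what is new or still open speak of the compounds shown alone.

In a functional assay on MT4 cells (Homo sapiens) for cytotoxicity (on this read-out higher numbers stand for lower toxicity in this test and lower numbers for higher toxicity in this test), compound 3 (`CC(C)Sc1nc(O)cc(C(C)c2c(F)cccc2F)n1`) gives 167000 nM, compound 2 (`CCC(c1cc(O)nc(SC(C)C)n1)c1c(F)cccc1F`) gives 130000 nM and compound 1 (`CCC(c1ccccc1)c1cc(O)nc(SC2CCCCC2)n1`) gives 51000 nM. Compound 3 lies within the scatter of compound 2, while the gap between compound 3 and compound 1 exceeds the scatter, with compound 3 the higher on this scale. Among the compounds with values here, the one measured step (a 1.3-fold higher number from compound 2 to compound 3 (0.11 log units; within the scatter)) concerns a methyl on the chain and not the group on sulfur, so it offers little guidance here. Compound 4 (`CC(c1cc(O)nc(SC2CCCCC2)n1)c1c(F)cccc1F`) differs from compound 3 by cyclohexyl in place of isopropyl on a sulfur. Compound 1 also carries cyclohexyl on a sulfur, and its 51000 nM is the only hint, although it differs elsewhere too. A modest fall in this assay is therefore expected, and the estimated step is a 2.1-fold lower number from compound 3 to compound 4 (0.32 log units; beyond the scatter) (a tentative figure). Compound 4 is expected at 80000 nM (35000 nM to 170000 nM).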

Compound 4, half-maximal cytotoxic concentration: > 200000 nM
Compound 4: a limit, no number; the forecaster's own chance of this, stated with the estimate: 10%; at least 2.5-fold (0.39 log units) between middle value and limit.
By their numbers in this assay, from the lowest: compound 1; then compounds 2 and 3 (each within the scatter of the next). At a limit, above all of these: compound 4.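

Compound 4 gives > 200000 nM in this assay, which is a limit of the assay and not a number. Within the data shown here, this is the first pair that changes only the group on the sulfur, and the step reads an at least 1.1-fold higher number from compound 3 to compound 4 (0.07 log units; that floor lies within the scatter), so cyclohexyl in place of isopropyl brings no fall on this read-out. From the compounds shown here alone, its true size stays unknown, since the floor of that step lies within the scatter. Still open, going by these compounds, is how an amine or a carboxylic acid on the same sulfur would read, and whether a longer chain such as n-hexyl would behave like the cyclohexyl ring.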